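The compounds below may be only part of what the source reports. "The series", "measured", "known", "first", "only" and "open" are said of these compounds alone.

Measured compounds:
compound 1 `O=S1(=O)C=Cc2cccc(Nc3ccc(C(F)(F)F)cc3)c21` gives 2440 nM
compound 2 `COc1ccc(Nc2cccc3c2S(=O)(=O)C=C3)cc1` gives 2590 nM
compound 3 `COc1ccccc1Nc1cccc2c1S(=O)(=O)C=C2` gives 2590 nM

All three were tested in a functional assay on A549 cells (Homo sapiens) for antiproliferative activity, read by MTT assay, with a stated time of 72 h; on this read-out lower numbers stand for stronger inhibition and higher numbers for weaker inhibition. Compound 2 and compound 3 carry the same atoms joined differently; how the two differ is not broken down here. Compound 1 stands beside compound 2 through one change, (trifluoromethyl in place of methoxy on an aromatic carbon), and the step it made was a 1.1-fold lower number from compound 2 to compound 1 (0.03 log units; within the scatter). Compound 3 stands level with compound 2 at the digits printed, and the two together hold the highest numbers of the three, while compound 1 sits within the scatter of both.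

Compound 4 `O=S1(=O)C=Cc2cccc(Nc3ccccc3C(F)(F)F)c21` has not yet been measured. It arises from compound 3 by trifluoromethyl in place of methoxy on an aromatic carbon. This is the same kind of change as that from compound 2 to compound 1, though not the same: there the new group sat para to a large group, here it sits ortho to a large group. Because the earlier step was a 1.1-fold lower number from compound 2 to compound 1 (0.03 log units; within the scatter), the estimated step in this assay is a 1.0-fold lower number from compound 3 to compound 4 (0.02 log units; within the scatter). Compound 4 is therefore expected to give about 2500 nM, likely between 1200 nM and 5500 nM.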

Compound 4, half-maximal inhibitory concentration: 4120 nM
The estimate for compound 4 lay 1.6-fold (0.22 log units) below the measured number, and the stated range covers the measured number.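

In this assay, the replacement of methoxy by trifluoromethyl on an aromatic carbon, now seen a second time, gave a 1.6-fold higher number from compound 3 to compound 4 (0.20 log units; within the scatter). Set beside the earlier case, the two steps cannot be told apart: the same change on two cores in this assay, a 1.1-fold lower number (0.03 log units; within the scatter) from compound 2 to compound 1 and a 1.6-fold higher number (0.20 log units; within the scatter) from compound 3 to compound 4, 1.7-fold (0.23 log units) apart, within the scatter of two such steps. This shows that, in these two pairs, the change moved the number by no more than repeated measurements would, so nothing here speaks against carrying it from one core to the other; it does not show that the step would hold on any further core, and it cannot separate any effect of the group sitting ortho to a large group in compound 4 from scatter.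

The compounds shown carry only methoxy or trifluoromethyl on the aromatic ring that changes, so what a nitrile, an amine or a carboxylic acid would give in that place remains open. All four numbers also come from this assay alone, which leaves open whether the same picture would hold on any other read-out.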